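Compound 4: (4-methylphenyl)amino in place of azetidin-1-yl

A few compounds are considered here, and "the series" means these few. Any claim that something is new, unique, unknown or untested is made for them only; others in the source may bear on it.

Compound 1 `O=C1C=C(N2CCC2)C(=O)c2c1nc1n2[C@H]2OC[C@@H](O)[C@H]2OC1` carries azetidin-1-yl on a double-bonded ring carbon of the shared core. In a functional assay on HeLa cells (Homo sapiens) for inhibition, read by sulforhodamine B assay (on this read-out lower numbers stand for stronger inhibition and higher numbers for weaker inhibition), compound 1 gives only a limit of the assay, > 16000 nM. Compound 2 `O=C1C(NC2CCCC2)=CC(=O)c2c1nc1n2[C@H]2OC[C@@H](O)[C@H]2OC1` carries cyclopentylamino at that carbon; in this assay compound 2 likewise stays at a limit, > 16000 nM. Compound 3 `O=C1C(N2CCCCC2)=CC(=O)c2c1nc1n2[C@H]2OC[C@@H](O)[C@H]2OC1` carries piperidin-1-yl; in this assay compound 3 also reaches only a limit, > 16000 nM. For the measured compounds named here, the single measured step, a step that the two limits leave unreadable from compound 2 to compound 3, therefore cannot be read for size or direction, and compound 1 stands at the same limit as the other two values, as summarised by the limit of > 16000 nM in this assay, at which 3 of the 3 values shown sit.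

Compound 4 `Cc1ccc(NC2=CC(=O)c3nc4n(c3C2=O)[C@H]2OC[C@@H](O)[C@H]2OC4)cc1` differs from compound 1 by (4-methylphenyl)amino in place of azetidin-1-yl on a double-bonded ring carbon. Going by the values given here, no measured step covers this kind of change: the one step, piperidin-1-yl for cyclopentylamino, is unreadable, and no value below the limit exists among the three compounds. The expectation for this assay is therefore no readable step, with the result most likely to remain a limit; the step from compound 1 is estimated as a step that the limit leaves unreadable from compound 1 to compound 4. Compound 4 is expected at about 20000 nM, with a range from 5000 nM to 60000 nM.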

Compound 4, half-maximal inhibitory concentration: 3860 nM
Compound 4: the middle estimate sits 5.2-fold (0.71 log units) above what was measured; measured number outside the range, below it.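

At this double-bonded ring carbon, (4-methylphenyl)amino in place of azetidin-1-yl gives the first readable change in the series shown, an at least 4.1-fold lower number from compound 1 to compound 4 (0.61 log units; beyond the scatter), in this assay, whereas the only earlier step, between compound 2 and compound 3, cannot be read. The change therefore shows that substitution at this carbon can bring a compound on this core within the measurable range of the assay, although the size of the step is only a lower bound, as the number for compound 1 is a limit. Compound 4 is the only compound shown that leaves that limit: the limit of > 16000 nM in this assay, at which 3 of the 4 values shown sit.

The exchange adds a six-membered aromatic ring of carbon only and a hydrogen-bond donor, and it also replaces a four-membered ring and enlarges the group, so the compounds shown do not assign the lower number to any one of these features or to the methyl. Phenylamino, benzylamino and N-methyl-(4-methylphenyl)amino at this carbon would separate the contributions of the methyl, the directly attached aromatic ring and the amine hydrogen, and how far the number can fall remains open.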